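The source may hold more compounds than are shown below. What is called first, only, known or untested is meant among the compounds shown, and "the series" means these compounds.

Measured in an ADME assay on Vero cells (Chlorocebus sabaeus) for cytotoxicity, read by MTT assay, with a stated time of 72 h; on this read-out higher numbers stand for weaker inhibition and lower numbers for stronger inhibition:
compound 1 `O=[N+]([O-])c1c[nH]c(-c2nnc(-c3cc4cc(Cl)ccc4[nH]3)o2)c1`: 329000 nM
compound 2 `COc1ccc(-c2nnc(-c3cc([N+](=O)[O-])c[nH]3)o2)cc1`: 409000 nM
compound 3 `Cn1cc([N+](=O)[O-])cc1-c1nnc(-c2cc(-c3ccccc3)nc3ccc(Cl)cc23)o1`: 328000 nM

In this assay compound 1 stands second highest of the three numbers. Its nearest neighbour, compound 3, and its furthest, compound 2, both lie within the scatter of compound 1, so no order can be read among the three.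

Compound 4 `Cn1cc([N+](=O)[O-])cc1-c1nnc(-c2cc3cc(Cl)ccc3[nH]2)o1` has not yet been measured. It differs from compound 1 by methyl in place of hydrogen on an aromatic nitrogen. Among the measured compounds shown here, no pair of measured compounds isolates this single change; compound 3, which also carries a methyl on that nitrogen of the shared core, gives a number that does not separate from compound 1.

The step expected in this assay is a 1.0-fold higher number from compound 1 to compound 4 (0.00 log units; within the scatter), none beyond the scatter in either direction. Compound 4 is therefore expected at 330000 nM, with a range from 200000 nM to 550000 nM.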

Compound 4, half-maximal inhibitory concentration: 743000 nM
The estimate for compound 4 lay 2.3-fold (0.35 log units) below the measured number; measured number outside the range, above it.
By their numbers in this assay, from the lowest: compounds 3, 1, 2 and 4 (each within the scatter of the next, the first and the last beyond it).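

In this assay, among the compounds shown here, methyl in place of hydrogen on the aromatic nitrogen gives a 2.3-fold higher number from compound 1 to compound 4 (0.35 log units; beyond the scatter) and so moves toward weaker inhibition, the only step so far that can be read beyond the scatter. This position is therefore not silent on the core of compound 1. Nothing measured here accounts for the step.

For the compounds shown here, only this one pair isolates the change, so whether the step holds on any other core stays open. Also open, on these data alone, is how a longer chain such as ethyl, or a carboxylic acid, on that nitrogen would read.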